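The compounds below may be only part of what the source reports. "The series", "measured", "known", "first", "only" and "open" are said of these compounds alone.

Compound 1 `CSc1cc(NC(C)=O)nc2[nH]cnc12` gives in a functional assay on KB cells (Homo sapiens) for cytotoxicity (a higher number here means that more compound is needed for the effect, a lower number that less compound is needed), a result of > 22 ug/mL, which is a limit of the assay rather than a number.
Compound 2 `Cc1ccc(S(=O)(=O)/N=c2\cc(Cl)c3ncn4c3n2C[C@H]2O[C@@H]4[C@@H]3OC(C)(C)O[C@@H]32)cc1` gives in this assay a result of > 22 ug/mL, again a limit.
Compound 3 `Nc1cc(Cl)c2ncn([C@@H]3O[C@H](CO)[C@@H](O)[C@H]3O)c2n1` gives in this assay a result of > 22 ug/mL, again a limit.

Compound 1 thus stands at the limit of > 22 ug/mL in this assay, at which 3 of the 3 values shown sit; no measured number separates it from the other two compounds, each of which also sits at that limit. Compound 4 `CSc1cc(N)nc2[nH]cnc12` differs from compound 1 in one place: hydrogen in place of acetyl on a nitrogen on an aromatic ring. Going by the values given here, no measured pair of compounds shows what such a change does here, so no shift beyond the usual scatter is expected in this assay in either direction. Compound 4 is therefore estimated to remain at the limit, around 30 ug/mL with a range from 10 ug/mL to 100 ug/mL. That estimate means an expected step that the limit leaves unreadable from compound 1 to compound 4.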

Compound 4, concentration for half-maximal effect: > 22 ug/mL
Compound 4 was reported as a limit; the forecaster's own chance of this, stated with the estimate: 80%; the middle value lies beyond the limit too.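

Compound 1 and compound 4 both give only a limit, so no step between them can be read: the limit of > 22 ug/mL in this assay, at which 4 of the 4 values shown sit.

The compounds shown leave open how much of each is needed for the effect in this assay, and whether going from acetamido to amino changes that amount.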